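Cytotoxicity notes on compounds 1 to 4

The source may hold more compounds than are shown below. What is called first, only, known or untested is meant among the compounds shown, and "the series" means these compounds.

In a functional assay on cells (Peritoneal macrophage, Mus musculus) for cytotoxicity, with a stated time of 24 h (on this read-out higher numbers stand for lower toxicity in this test and lower numbers for higher toxicity in this test), compound 1 `COc1ccc(S(=O)(=O)N(CC(N)=O)c2ccc(N(CC(N)=O)S(=O)(=O)c3ccc(NC(C)=O)cc3)c3ccccc23)cc1` gives > 50000 nM, which is a limit of the assay.
In this assay compound 2 `CCCCC(=O)Nc1ccc(S(=O)(=O)N(CC(N)=O)c2ccc(N(CC(N)=O)S(=O)(=O)c3ccc(OC)cc3)c3ccccc23)cc1` gives > 100000 nM, also a limit.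
In this assay compound 3 `COc1ccc(S(=O)(=O)N(CC(N)=O)c2ccc(N(CC(N)=O)S(=O)(=O)c3ccc(NC(=O)CN4CCCCC4)cc3)c3ccccc23)cc1` gives > 100000 nM, again a limit.

Compound 3 therefore stands only at a limit, as do the two other values shown; the limit of > 100000 nM in this assay, at which 2 of the 3 values shown sit, holds two of them and the limit of > 50000 nM in this assay, at which 1 of the 3 values shown sits, one. The steps a step that the two limits leave unreadable from compound 1 to compound 2, a step that the two limits leave unreadable from compound 1 to compound 3 and a step that the two limits leave unreadable from compound 2 to compound 3 are all unreadable between limits. Compound 4 `CCN1CCN(CC(=O)Nc2ccc(S(=O)(=O)N(CC(N)=O)c3ccc(N(CC(N)=O)S(=O)(=O)c4ccc(OC)cc4)c4ccccc34)cc2)CC1` differs from compound 3 by 4-ethylpiperazin-1-yl in place of piperidin-1-yl on a saturated chain carbon bound to a carbonyl carbon. The steps bearing on this change, from compound 1 or compound 2 to compound 3, gave no readable size, so no step beyond the scatter is expected; a step that the limit leaves unreadable from compound 3 to compound 4 is the expected step. For compound 4 the estimate in this assay is 150000 nM, within 70000 nM to 400000 nM, most likely reported again as a limit.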

Compound 4, half-maximal cytotoxic concentration: > 100000 nM
Compound 4 was reported as a limit (the forecaster's own chance of this, stated with the estimate: 85%); the middle value is on the limit's open side.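

All four values are limits, so the steps from compound 1, compound 2 and compound 3 to compound 4 cannot be read. The compounds shown leave open whether any cytotoxicity difference exists among these four compounds, and how large it is.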